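This account rests on a few compounds, and the source may have more. Where it says the series, first, only, none or still open, it means among the compounds named here.

Compound 1 `CN1CCN(CCCN(c2nc3cc(Cl)c(Cl)cc3[nH]2)[C@@H]2CC[C@]3(c4cccc(C#N)c4)C[C@@H]3C2)CC1` and compound 2 `CN1CCN(CCCN(c2nc3cc(F)c(Cl)cc3[nH]2)[C@@H]2CC[C@]3(c4cccc(C#N)c4)C[C@@H]3C2)CC1` share one core, while compound 3 `CN1CCN(CCCN(c2nc3cc(Cl)c(Cl)cc3[nH]2)[C@@H]2CC[C@]3(c4ccc(C#N)cc4)C[C@H]23)CC1` and the as yet unmeasured compound 4 `CN1CCN(CCCN(c2nc3cc(F)c(Cl)cc3[nH]2)[C@@H]2CC[C@]3(c4ccc(C#N)cc4)C[C@H]23)CC1` share another; the difference between the two cores is not broken down here. In an assay on isolated protein for binding affinity to melanin-concentrating hormone receptor 1 (Homo sapiens) (a lower number here means a stronger inhibitor, a higher number a weaker inhibitor), compound 1 gives 2.2 nM, compound 2 gives 6.2 nM and compound 3 gives 11.4 nM. Within the first core, the change fluoro in place of chloro on an aromatic carbon brought a 2.8-fold higher number from compound 1 to compound 2 (0.45 log units; beyond the scatter). The same change, (fluoro in place of chloro on an aromatic carbon), now takes compound 3 to compound 4. Because the earlier step of a 2.8-fold higher number from compound 1 to compound 2 (0.45 log units; beyond the scatter) was modest but beyond the scatter, a step of similar size is expected for the second pair, namely a 2.6-fold higher number from compound 3 to compound 4 (0.42 log units; beyond the scatter). On that basis compound 4 is estimated at 30 nM, with a likely range from 12 nM to 75 nM.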

Compound 4, inhibition constant: 4.9 nM
Compound 4: middle estimate off by 6.1-fold (0.79 log units), on the high side; the whole stated range lies above it.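

In this assay fluoro in place of chloro gave a 2.3-fold lower number from compound 3 to compound 4 (0.37 log units; beyond the scatter) and so a stronger inhibitor, whereas the same swap gave a weaker inhibitor when made on compound 1. These two pairs show that the result of this swap cannot simply be carried from one core to the other in this series, but they do not show which difference between the cores turns it around, or how it would go on a further core. The two steps run in opposite directions: the same change on two cores in this assay, a 2.8-fold higher number (0.45 log units; beyond the scatter) from compound 1 to compound 2 and a 2.3-fold lower number (0.37 log units; beyond the scatter) from compound 3 to compound 4, 6.6-fold (0.82 log units) apart, beyond the scatter of two such steps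

The compounds shown leave open how other groups in place of chloro, such as bromo or methoxy, would behave on each core.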